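Permeability notes: dimethylbenzyl in place of cyanobenzyl

The compounds below may be only part of what the source reports. "The series", "measured", "known", "first", "only" and "open" are said of these compounds alone.

In an ADME assay for permeability, using PAMPA, with a stated time of 30 min, at pH 7.4 (on this read-out lower numbers stand for lower permeability and higher numbers for higher permeability), compound 3 `COc1cccc(CNCCCNc2ccnc3cc(Cc4ccc(C#N)cc4)ccc23)c1O` gives 23 10^-6 cm/s. Compound 1 `COc1ccc(F)cc1CNCCCNc1ccnc2cc(Cc3cc(C)cc(C)c3)ccc12` gives 23 10^-6 cm/s in this assay, level with compound 3 at the digits printed, so the two stand together at the low end of the three numbers. For the measured compounds named here, compound 2 `COc1ccc(Oc2ccc3c(NCCCNCc4cccc(OC)c4O)ccnc3c2)cc1` gives 317 10^-6 cm/s, and the only single-point step recorded, a 14-fold lower number from compound 2 to compound 3 (1.14 log units; beyond the scatter), separates compound 2 from compound 3.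

Compound 4 `COc1cccc(CNCCCNc2ccnc3cc(Cc4cc(C)cc(C)c4)ccc23)c1O` is not yet measured in this assay. It differs from compound 3 at the saturated chain carbon bound to an aromatic carbon: 3,5-dimethylphenyl in place of 4-cyanophenyl on a saturated chain carbon bound to an aromatic carbon. Going by the values given here, no measured step covers this exchange directly. The step from compound 2 to compound 3 bears only on the 4-cyanobenzyl side, and compound 1, which already carries the 3,5-dimethylbenzyl group, shows the same number as compound 3. The expectation is therefore a step of a 1.3-fold higher number from compound 3 to compound 4 (0.12 log units; within the scatter) for compound 4, within the scatter. Compound 4 is estimated at 30 10^-6 cm/s, with a range from 10 10^-6 cm/s to 90 10^-6 cm/s.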

Compound 4, apparent permeability: 23 10^-6 cm/s
For compound 4 the middle estimate is 1.3-fold (0.12 log units) above the measured one, within the range that was stated.
By their numbers in this assay, from the lowest: compounds 1, 3 and 4 (each within the scatter of the next); then compound 2.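

In this assay, 3,5-dimethylphenyl in place of 4-cyanophenyl gives no change at the digits printed from compound 3 to compound 4 (within the scatter), so at this position the loss of the nitrile leaves the number as it was. For the compounds shown here, the step of 3,5-dimethylbenzyl in place of 4-methoxyphenoxy, a 14-fold lower number from compound 2 to compound 4 (1.14 log units; beyond the scatter), shows that the large step seen with 4-cyanobenzyl recurs with a second benzyl group, while 2-hydroxy-3-methoxyphenyl in place of 5-fluoro-2-methoxyphenyl gives no change at the digits printed from compound 1 to compound 4 (within the scatter), a reading at the amine end that the earlier compounds did not give. No measurement on hand accounts for any of these steps.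

Still open, from the compounds shown here alone, is whether 4-methoxybenzyl on the aromatic carbon would stay at the level of compound 4 or approach compound 2. Also open, going by these compounds, is whether a carboxylic acid or an amine on the benzyl ring would depart from this level.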